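Aryl ester variation in a urotensin-2 receptor series

The source may report more compounds than this note shows. Statements on the series, on what has been measured and on what is new or still open speak of the compounds shown alone.

Measured compounds:
compound 1 `Cc1ccccc1C(=O)OC(CCN(C)C)c1ccc(Cl)cc1`: 1700 nM
compound 2 `COc1ccc(C(=O)OC(CCN(C)C)c2ccc(Cl)cc2)cc1`: 2190 nM
compound 3 `CN(C)CCC(OC(=O)c1ccc(C(F)(F)F)cc1)c1ccc(Cl)cc1`: 1740 nM

All three measured compounds share one core and differ only in the aryl group on the carbonyl carbon. In an assay on NIH3T3 cells with Urotensin-2 receptor (Homo sapiens) as the target (on this read-out lower numbers stand for an effect already at smaller amounts and higher numbers for an effect only at larger amounts of compound), compound 2 shows the highest of the three numbers, yet both other compounds lie within the scatter of it: a 1.3-fold higher number from compound 1 to compound 2 (0.11 log units; within the scatter) and a 1.3-fold lower number from compound 2 to compound 3 (0.10 log units; within the scatter). Compound 4 `Cc1cccc(C(=O)OC(CCN(C)C)c2ccc(Cl)cc2)c1C` differs from compound 2 by 2,3-dimethylphenyl in place of 4-methoxyphenyl on a carbonyl carbon. Both measured steps bear on this change, since each also exchanged the aryl group on the carbonyl carbon, and neither left the scatter; no step beyond the scatter is therefore expected in this assay. Compound 4 is estimated at 1800 nM, with a range from 900 nM to 3600 nM. This corresponds to an expected step of a 1.2-fold lower number from compound 2 to compound 4 (0.09 log units; within the scatter).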

Compound 4, half-maximal effective concentration: 1150 nM
Compound 4: middle estimate off by 1.6-fold (0.19 log units), on the high side; low and high end bracket the measured number.
By their numbers in this assay, from the lowest: compounds 4, 1, 3 and 2 (each within the scatter of the next).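

Among the compounds shown here, on the carbonyl carbon, 2,3-dimethylphenyl in place of 4-methoxyphenyl gives the largest step so far in this assay, a 1.9-fold lower number from compound 2 to compound 4 (0.28 log units; within the scatter), so an aryl group without a hydrogen-bond acceptor still stays within the scatter. Methyl in place of hydrogen on an aromatic carbon also stays within it, a 1.5-fold lower number from compound 1 to compound 4 (0.17 log units; within the scatter). Nothing available explains either step. Open, going by these compounds, is whether an aryl group carrying an amine or a carboxylic acid, or a longer alkyl chain in place of the aryl group, would leave the scatter.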